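This account rests on a few compounds, and the source may have more. Where it says the series, first, only, none or still open, it means among the compounds named here.

Measured in a functional assay on PC-3 cells (Homo sapiens) for inhibition, read by sulforhodamine B assay, with a stated time of 48 h; on this read-out higher numbers stand for weaker inhibition of growth and lower numbers for stronger inhibition of growth:
Compound 1 `CCOC(=O)c1nn(-c2ccccc2)c(-c2ccc(F)cc2)c1CNC(C)(C)C`: 69300 nM; 82100 nM (2 entries)
Compound 2 `CCOC(=O)c1nn(-c2ccc(Cl)cc2)c(-c2ccc(Cl)cc2)c1CNC(C)(C)C`: 196000 nM; > 519000 nM (2 entries)
Compound 3 `CC(C)(C)NCc1c(C(=O)O)nn(-c2ccccc2)c1-c1ccc(F)cc1`: > 680000 nM, a limit

Compound 3 has no single number in this assay, only its limit of > 680000 nM and two further entries without a number. Compound 4 `CC(C)(C)NCc1c(C(=O)O)nn(-c2ccccc2)c1-c1ccccc1` differs from it by hydrogen in place of fluoro on an aromatic carbon, para to a large group (hydrogen in place of fluoro on an aromatic carbon). Among the compounds with values here, no measured pair isolates this change, so the expectation rests on compound 3 alone, at its limit of > 680000 nM. The estimated step that the limit leaves unreadable from compound 3 to compound 4 is expected to stay within the scatter, with no direction favoured. Compound 4 is estimated at 700000 nM, with an expected range of 350000 nM to 900000 nM, and may well be reported only as a limit.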

Compound 4, concentration for 50% growth inhibition: > 716000 nM
Compound 4: a limit, no number; the forecaster's own chance of this, stated with the estimate: 75%; middle value at least 1.0-fold (0.00 log units) away from the limit.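

Compound 3 and compound 4 are each reported only as a limit, so the step between them cannot be read. The compounds shown leave open whether going from 4-fluorophenyl to phenyl changes growth inhibition at all.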